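The compounds below may be only part of what the source reports. "The series", "measured", "known", "first", "only" and "open" are said of these compounds alone.

Series notes: three compounds share a core, built from compound 1 `O=C(O)c1ccc(CN2C(=O)S/C(=C\c3cccnc3)C2=O)cc1`, compound 2 `O=C(O)c1ccc(CN2C(=O)S/C(=C\c3ccncc3)C2=O)cc1` and compound 3 `COc1cccc(/C=C2\SC(=O)N(Cc3ccc(C(=O)O)cc3)C2=O)c1`. All were tested in a functional assay on HT-29 cells (Homo sapiens) for cytotoxicity, read by MTT assay, with a stated time of 24 h; a higher number here means a weaker inhibitor, a lower number a stronger inhibitor. Compound 1 gives 90000 nM; compound 2 gives 80000 nM; compound 3 gives 48000 nM. Compound 1 cannot be separated from the other two: the step of a 1.1-fold lower number from compound 1 to compound 2 (0.05 log units; within the scatter) and the step of a 1.9-fold lower number from compound 1 to compound 3 (0.27 log units; within the scatter) both fall inside the scatter, as does the step of a 1.7-fold lower number from compound 2 to compound 3 (0.22 log units; within the scatter), so the three numbers form one cluster of weak inhibitors.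

Compound 4 `Cc1ccc(/C=C2\SC(=O)N(Cc3ccc(C(=O)O)cc3)C2=O)cc1` is the next member, not yet measured in this assay. Relative to compound 1 the change is 4-methylphenyl in place of pyridin-3-yl on a double-bonded chain carbon bound to a double-bonded ring carbon. Going by the values given here, the steps that bear on it are the two exchanges of the same ring already seen: from compound 1 to compound 2 the aromatic ring changed and the number barely moved, and from compound 1 to compound 3 a six-membered carbon-only ring carrying a methoxy group entered and the number again stayed within the scatter. Nothing in these data shows that swapping this ring shifts the read-out beyond noise. The expectation for compound 4 is therefore a step of a 1.4-fold lower number from compound 1 to compound 4 (0.14 log units; within the scatter) of no real size, with the estimate for compound 4 in this assay at 65000 nM, between 25000 nM and 160000 nM.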

Compound 4, half-maximal inhibitory concentration: 72000 nM
The estimate for compound 4 lay 1.1-fold (0.04 log units) below the measured number, and the stated range covers the measured number.
By their numbers in this assay, from the lowest: compounds 3, 4, 2 and 1 (each within the scatter of the next).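

In this assay, 4-methylphenyl on a double-bonded chain carbon bound to a double-bonded ring carbon removes the ring nitrogen and the hydrogen-bond acceptor of pyridin-3-yl and brings in a methyl group, yet a 1.3-fold lower number from compound 1 to compound 4 (0.10 log units; within the scatter) stays inside the scatter. The comparisons with the other two rings read the same way, with a 1.1-fold lower number from compound 2 to compound 4 (0.05 log units; within the scatter) and a 1.5-fold higher number from compound 3 to compound 4 (0.18 log units; within the scatter), so the four compounds remain a single cluster, and neither a ring nitrogen, a methoxy group nor a methyl group separates any of them at this position. No supporting data are available to explain this flat response.

The compounds shown carry only six-membered aromatic rings at this position, so it remains open whether a primary amine or a hydroxyl group on the ring, a longer chain such as butyl, or a five-membered ring in its place would move the number beyond the scatter. Also open, going by these compounds, is whether any change at this position can lift the series out of this weak range, or whether that depends on another part of the shared core, such as the carboxylic acid.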